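The source may hold more compounds than are shown below. What is called first, only, known or untested is meant among the compounds shown, and "the series" means these compounds.

Measured so far:
compound 1 `CCCCn1c(CCC)nc2cc(N)ccc21` — 56.8%
compound 2 `CCCCCn1c(CCC)nc2cc(N)ccc21` — 54.4%

In a functional assay on the whole organism with Rattus norvegicus as the target, read by paw edema, with a stated time of 5 h, at a dose of 25 mg/kg by the oral route (a higher number here means a stronger effect of the compound at the dose given, a lower number a weaker effect), compound 1 gives 56.8%, and compound 2 gives 54.4%. Compound 2 has the lower of the two numbers, but the step of a number 2.4 percentage points lower from compound 1 to compound 2 (within the scatter) lies within the scatter, so the two compounds cannot be separated on these data.

Compound 3 `CCCCCCn1c(CCC)nc2cc(N)ccc21` has not yet been measured. It differs from compound 2 by methyl in place of hydrogen on a saturated chain carbon, five bonds along the chain from an aromatic nitrogen. Within the data shown here, the one step that bears on it is the homologous one, a number 2.4 percentage points lower from compound 1 to compound 2 (within the scatter), which was within the scatter. On that basis no change beyond the scatter is expected in this assay for compound 3, and the estimated step is a number 2.4 percentage points lower from compound 2 to compound 3 (within the scatter).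

For compound 3 the expected value in this assay is 52%, with a range from 40% to 64%.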

Compound 3, a percentage reported as activity, at one dose (the size of the read-out at that dose, not a potency): 49.8%
The estimate for compound 3 lay 2.2 percentage points above the measured number, within the range that was stated.
By their numbers in this assay, from the lowest: compounds 3, 2 and 1 (each within the scatter of the next).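

In this assay, methyl in place of hydrogen on a saturated chain carbon, five bonds along the chain from an aromatic nitrogen, gives a number 4.6 percentage points lower from compound 2 to compound 3 (within the scatter) and so adds a second chain position at which this change cannot be separated from the scatter. The two changes taken together give a number 7 percentage points lower from compound 1 to compound 3 (within the scatter) and show that the larger change also stays inside the scatter, leaving all three compounds unseparated in this assay. No supporting data beyond these paw edema numbers bear on this result.

From the compounds shown here alone, whether a longer chain such as octyl would give a step beyond the scatter remains open. Also open, going by these compounds, is how a chain ending in a carboxylic acid or a hydroxyl group would read at this dose.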